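Dichlorophenyl Urea Expected to Hold Modest Kinase Inhibition

A few compounds are considered here, and "the series" means these few. Any claim that something is new, unique, unknown or untested is made for them only; others in the source may bear on it.

Of the compounds shown here, three built on a shared core have been measured in an assay on isolated protein for inhibition of serine/threonine-protein kinase PAK 1 (Homo sapiens), read by ADP-Glo, with a stated time of 40 min; on this read-out higher numbers stand for weaker inhibition and lower numbers for stronger inhibition. Compound 1 `O=C(NC1CCN(c2ncnc3[nH]ncc23)CC1)c1ccc(Br)cc1` gives 16400 nM, compound 2 `O=C(NC1CCN(c2ncnc3[nH]ncc23)CC1)c1cccc(Cl)c1Cl` gives 4170 nM, and compound 3 `Cc1ccc(NC(=O)NC2CCN(c3ncnc4[nH]ncc34)CC2)cc1` gives 4710 nM. Among these, compound 3 stands second highest, within the scatter of compound 2 and clearly apart from compound 1, as a 3.5-fold lower number from compound 1 to compound 3 (0.54 log units; beyond the scatter) shows. The new compound 4 `O=C(Nc1ccc(Cl)c(Cl)c1)NC1CCN(c2ncnc3[nH]ncc23)CC1` differs from compound 3 in one place: 3,4-dichlorophenyl in place of 4-methylphenyl on an amide-type nitrogen. Two earlier steps bear on this. Introducing two chlorines on the aromatic ring gave a 3.9-fold lower number from compound 1 to compound 2 (0.59 log units; beyond the scatter), while switching the amide to the urea gave a 1.1-fold higher number from compound 2 to compound 3 (0.05 log units; within the scatter). Since a dichlorinated ring brought a modest improvement once, a comparable or smaller gain is expected here for compound 4, with a 1.6-fold lower number from compound 3 to compound 4 (0.20 log units; within the scatter) as the estimated step in this assay. Compound 4 is therefore expected to give about 3000 nM, likely between 800 nM and 12000 nM.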

Compound 4, half-maximal inhibitory concentration: 2290 nM
Compound 4: the middle estimate sits 1.3-fold (0.12 log units) above what was measured; the measured number falls inside the stated range.
By their numbers in this assay, from the lowest: compounds 4, 2 and 3 (each within the scatter of the next, the first and the last beyond it); then compound 1.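

In this assay, among these compounds, the result gives the first step made on the aryl group of the urea itself: 3,4-dichlorophenyl in place of 4-methylphenyl on the amide-type nitrogen gives a 2.1-fold lower number from compound 3 to compound 4 (0.31 log units; beyond the scatter) and so shows that the reading responds to this group, which the earlier compounds could not show. The urea compound 4 cannot be told apart from the amide compound 2, with a 1.8-fold lower number from compound 2 to compound 4 (0.26 log units; within the scatter) as the step between them, yet it stands well clear of the bromophenyl amide, with a 7.2-fold lower number from compound 1 to compound 4 (0.86 log units; beyond the scatter) as the largest step in the set. Nothing shown here explains this change in the reading. The compounds shown leave open whether a single chlorine on the ring would do as much as two. They also leave open how an amine, a carboxylic acid or a longer chain on that ring would read.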